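This account rests on a few compounds, and the source may have more. Where it says the series, first, only, none or still open, it means among the compounds named here.

For the measured compounds named here, in a functional assay on HT-29 cells (Homo sapiens) for antiproliferative activity, read by sulforhodamine B assay, with a stated time of 48 h (a higher number here means a weaker inhibitor, a lower number a stronger inhibitor), three compounds that share one core have numbers so far. Compound 1 `O=C1NCCN1c1ccc(S(=O)(=O)Nc2ccc3[nH]ccc3c2)cc1` gives 130 nM, compound 2 `CCCCc1ccc(NS(=O)(=O)c2ccc(N3CCNC3=O)cc2)cc1` gives 610 nM, and compound 3 `Cc1ccc(NS(=O)(=O)c2ccc(N3CCNC3=O)cc2)cc1C` gives 230 nM. Compound 3 therefore lies within the usual scatter of compound 1, so those two cannot be told apart. Compound 2 has a higher number than compound 3 by more than the scatter, making it the weaker inhibitor of that pair.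

Compound 4 `CCc1cccc(NS(=O)(=O)c2ccc(N3CCNC3=O)cc2)c1` has not been measured yet. It has the same atoms as compound 3, joined differently, with 3-ethylphenyl in place of 3,4-dimethylphenyl on a sulfonamide nitrogen. Going by the values given here, no measured pair shows this kind of swap, so the guidance is thin. Only a small rise in this assay is expected, perhaps none beyond the scatter. The slight lean upward rests on compound 2, with its butyl chain, at 610 nM. The expected step is a 1.4-fold higher number from compound 3 to compound 4 (0.14 log units; within the scatter). For compound 4 the estimated value is 320 nM, with an expected range of 130 nM to 750 nM.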

Compound 4, half-maximal inhibitory concentration: 110 nM
The estimate for compound 4 lay 2.9-fold (0.46 log units) above the measured number; measured number outside the range, below it.
By their numbers in this assay, from the lowest: compounds 4, 1 and 3 (each within the scatter of the next, the first and the last beyond it); then compound 2.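

In this assay, putting 3-ethylphenyl in place of 3,4-dimethylphenyl on a sulfonamide nitrogen gives a 2.1-fold lower number from compound 3 to compound 4 (0.32 log units; beyond the scatter) as a modest step beyond the usual scatter. The two groups match in every count computed for them, including their heavy atoms and their single carbon-only aromatic ring, so this position responds to how the same carbons are arranged and not only to how many there are. No measured evidence accounts for the step.

This single pair cannot separate the effect of gaining the ethyl group from that of losing the two methyl groups. The compounds shown also leave open how this position would respond to a ring carrying an amine, a carboxylic acid or a methoxy group in place of these purely carbon substituents.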